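A Benzofuran Swap at the Assay Limit

This account rests on a few compounds, and the source may have more. Where it says the series, first, only, none or still open, it means among the compounds named here.

Compound 1 `CN(C)c1ncnc2c1c(-c1cc3ccccc3o1)cn2[C@@H]1O[C@H](CO)[C@@H](O)[C@H]1O` reads > 20000 nM (a limit)
Compound 2 `Cc1ncnc2c1c(-c1ccoc1)cn2[C@@H]1O[C@H](CO)[C@@H](O)[C@H]1O` reads > 20000 nM (a limit)
Compound 3 `Nc1nc2c(c(-c3ccco3)cn2[C@@H]2O[C@H](CO)[C@@H](O)[C@H]2O)c(=O)[nH]1` reads > 20000 nM (a limit)

In a functional assay on CEM-DNR-bulk cells (Homo sapiens), read by MTT assay, with a stated time of 72 h (a higher number here means a weaker inhibitor, a lower number a stronger inhibitor), compound 3 gives > 20000 nM, which is a limit of the assay and not a number. It shares this position with compound 1 and compound 2, and the whole set comes down to the limit of > 20000 nM in this assay, at which 3 of the 3 values shown sit. Among the measured compounds shown here, none of the three has yet produced a number, and no two of them differ in just one place, so no measured step is available as a guide.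

Compound 4 `Nc1nc2c(c(-c3cc4ccccc4o3)cn2[C@@H]2O[C@H](CO)[C@@H](O)[C@H]2O)c(=O)[nH]1` has not yet been measured. It differs from compound 3 on an aromatic carbon of a five-membered aromatic ring with 1 nitrogen, where 1-benzofuran-2-yl stands in place of furan-2-yl (1-benzofuran-2-yl in place of furan-2-yl on an aromatic carbon). Compound 1 also carries 1-benzofuran-2-yl, and it reads > 20000 nM, again a limit.

In this assay no step beyond the usual scatter is expected, and a further limit reading is the likeliest outcome. The expected step is a number no higher from compound 3 to compound 4 (the limit leaves the size open). For compound 4 the estimated value is 20000 nM, with an expected range from 7000 nM to 40000 nM.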

Compound 4, half-maximal inhibitory concentration: > 20000 nM
Compound 4: no number, only a limit (the forecaster's own chance of this, stated with the estimate: 80%); the middle value lies on the limit itself.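

In this assay compound 4 gives > 20000 nM, which is a limit of the assay and not a number. Among the compounds shown here, compound 3 also reads as a limit, and no step from compound 3 to compound 4 can be read. The compounds shown leave open how 1-benzofuran-2-yl compares with furan-2-yl, as every reading stands at one point: the limit of > 20000 nM in this assay, at which 4 of the 4 values shown sit.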